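Swapping Phenyl for Trifluoromethyl on Compound 1

The source may hold more compounds than are shown below. What is called first, only, known or untested is meant among the compounds shown, and "the series" means these compounds.

Compound 1 `C/C(=N/O)c1ccc(NC(=O)Cn2nc(-c3ccccc3)nc2N)cc1` was tested in a functional assay on HOP-62 cells (Homo sapiens) for inhibition, read by sulforhodamine B assay, with a stated time of 48 h, tested at 10 uM (a lower number here means less inhibition of growth, a higher number more inhibition of growth at the concentration tested), where compound 1 gives 17.7%, the lowest of the three numbers recorded. Compound 2 `c1ccc(-c2nc3sc(-c4ccccc4)cn3n2)cc1` gives 33%, and compound 3 `COc1ccc(-c2nc3sc(-c4ccc(Cl)cc4)cn3n2)cc1` gives 60.4%, both beyond the usual scatter above compound 1. Compound 4 `C/C(=N/O)c1ccc(NC(=O)Cn2nc(C(F)(F)F)nc2N)cc1` differs from compound 1 in one place: trifluoromethyl in place of phenyl on an aromatic carbon. Among the measured compounds shown here, no measured pair shows what this exchange does here, so the expectation rests on compound 1 alone. Because compound 1 gives 17.7%, a weak starting point, only a small expected shift is foreseen, a number 2.7 percentage points lower from compound 1 to compound 4 (within the scatter), not clearly beyond the scatter in either direction. Compound 4 is therefore estimated at 15%, within a range from 0% to 32%.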

Compound 4, percent growth inhibition at one concentration: 9.21%
Compound 4: middle estimate off by 5.8 percentage points, on the high side; the measured number falls inside the stated range.
By their numbers in this assay, from the lowest: compounds 4 and 1 (each within the scatter of the next); then compound 2; then compound 3.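

At this aromatic carbon of the five-membered ring, trifluoromethyl in place of phenyl gives a number 8.5 percentage points lower from compound 1 to compound 4 (within the scatter) in this assay. A group with no ring can therefore stand where the six-membered aromatic ring stood without a change beyond the scatter, although the reading of compound 1 was already weak, which leaves little room to see a loss. Nothing at hand explains this result.

Still open, going by these compounds, is what an amine, a carboxylic acid or a longer carbon chain on this same carbon would give, and whether any of them would move the number beyond the scatter.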